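The source may hold more compounds than are shown below. What is called first, only, known or untested is meant among the compounds shown, and "the series" means these compounds.

Working notes on the series. Among the compounds with values here, in an assay for inhibition of Amine oxidase [flavin-containing] A (Homo sapiens), read by fluorescence and spectrophotometry, using microsomes, with stated times of 30 min and 20 min (on this read-out higher numbers stand for weaker inhibition and lower numbers for stronger inhibition), compound 2 `CC(C)c1noc(-c2ccc(C3=NCCN3)cc2)n1` gives 22500 nM, the only number in hand. Compound 1 `N#Cc1ccc(C2=NCCN2c2ccc(C(F)(F)F)cn2)cc1` returns only a limit in this assay, > 100000 nM. Within the data shown here, that limit is the point described as the limit of > 100000 nM in this assay, at which 1 of the 2 values shown sits, and between one number and one limit no step can be counted. Compound 3 `Clc1ccccc1-c1noc(-c2ccc(C3=NCCN3)cc2)n1` has not yet been measured. It differs from compound 2 by 2-chlorophenyl in place of isopropyl on an aromatic carbon. Among the measured compounds shown here, no step between measured compounds is known, so the size of the change cannot be read from the series itself, and a shift beyond the scatter is possible in either direction. Compound 3 is expected to give about 10000 nM in this assay, with a range of 2000 nM to 50000 nM. That corresponds to an estimated step of a 2.3-fold lower number from compound 2 to compound 3 (0.35 log units; beyond the scatter).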

Compound 3, half-maximal inhibitory concentration: 17100 nM
For compound 3 the middle estimate is 1.7-fold (0.23 log units) below the measured one; the range from low to high includes it.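

In this assay, within the data shown here, 2-chlorophenyl in place of isopropyl on this aromatic carbon gives a 1.3-fold lower number from compound 2 to compound 3 (0.12 log units; within the scatter), the first step that can be read. Compounds 2 and 3 therefore cannot be told apart here, although the entering group brings a six-membered aromatic ring of carbon only and a chlorine to a place between two ring nitrogen atoms. Nothing in hand accounts for this outcome.

This single pair does not show whether other groups at this carbon would also stay within the scatter of compound 2. As far as these compounds go, what a plain phenyl, a primary amine or a carboxylic acid would give there stays open, as does the contribution of the chlorine within the 2-chlorophenyl group.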